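Moving the Trifluoromethyl Group on the Ring Borne by Nitrogen

The source may report more compounds than this note shows. Statements on the series, on what has been measured and on what is new or still open speak of the compounds shown alone.

Compound 1, `CCc1ccc(-n2nc(-c3ccc(C(F)(F)F)cc3O)nc2-c2ccccc2O)cc1`, gives 95.4% in a functional assay on PC-12 cells (Rattus norvegicus) for cytotoxicity, read by MTT assay, with stated times of 2 h and 24 h, tested at 5 uM; on this read-out higher numbers stand for a stronger effect at the one concentration tested and lower numbers for a weaker effect.
Compound 2, `Oc1cc(C(F)(F)F)ccc1-c1nc(-c2ccccc2O)n(-c2ccc(C(F)(F)F)cc2)n1`, gives 90.5% in this assay.
Compound 3, `Oc1cc(C(F)(F)F)ccc1-c1nc(-c2ccccc2O)n(-c2ccccc2F)n1`, gives 86.6% in this assay.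

Among these three numbers compound 2 stands second highest; its nearest neighbour is compound 3, and its furthest is compound 1, yet both gaps lie within the scatter, so the three compounds cannot be ranked on this evidence. Compound 4, `Oc1cc(C(F)(F)F)ccc1-c1nc(-c2ccccc2O)n(-c2cccc(C(F)(F)F)c2)n1`, has not been measured in this assay. It differs from compound 2 only in the ring that sits on the aromatic nitrogen: 3-(trifluoromethyl)phenyl in place of 4-(trifluoromethyl)phenyl on an aromatic nitrogen.

Among the measured compounds shown here, every measured step so far also exchanged that ring, and each stayed within the scatter: a number 4.9 percentage points lower from compound 1 to compound 2 (within the scatter), a number 8.8 percentage points lower from compound 1 to compound 3 (within the scatter) and a number 3.9 percentage points lower from compound 2 to compound 3 (within the scatter). Since all of these swaps, from an ethyl-bearing ring to fluorine- or trifluoromethyl-bearing rings, moved the number so little, a shift of the trifluoromethyl group from one position of the ring to another is not expected to produce a step beyond the scatter in this assay either. Compound 4 is therefore expected to give about 88%, with a likely range from 78% to 96%. The expected step is a number 2.5 percentage points lower from compound 2 to compound 4 (within the scatter), a change that is estimated to stay within the usual scatter.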

Compound 4, a percentage reported as activity, at one concentration (the size of the read-out at that concentration, not a potency): 92.2%
Estimate against measurement, compound 4: 4.2 percentage points below; the range from low to high includes it.
By their numbers in this assay, from the lowest: compounds 3, 2, 4 and 1 (each within the scatter of the next).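

Shifting the trifluoromethyl group on the ring at this nitrogen gives a number 1.7 percentage points higher from compound 2 to compound 4 (within the scatter) in this assay and is the first comparison here of one group in two placements on that ring; on this evidence, 3-(trifluoromethyl)phenyl and 4-(trifluoromethyl)phenyl cannot be told apart. The other new steps, a number 5.6 percentage points higher from compound 3 to compound 4 (within the scatter) and a number 3.2 percentage points lower from compound 1 to compound 4 (within the scatter), show that the new ring also cannot be separated from 2-fluorophenyl or 4-ethylphenyl at this position. No measurement shown here offers an explanation for these small steps.

Still open, as far as these compounds go, is whether a ring bearing an amine or a carboxylic acid, or a longer chain such as hexyl in place of ethyl, would give a step beyond the scatter. The single concentration tested also leaves open whether the four compounds would separate at lower concentrations.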